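Replacing an Amide Carbonyl in a Bile Acid Receptor Series

A few compounds are considered here, and "the series" means these few. Any claim that something is new, unique, unknown or untested is made for them only; others in the source may bear on it.

Compound 1 `CC(C)c1onc(-c2c(Cl)cccc2Cl)c1COc1ccc(N(C)C(=O)c2ccc(C(=O)O)cc2)c(C(F)(F)F)n1`: 316 nM
Compound 2 `Cc1nc(OCc2c(-c3c(Cl)cccc3Cl)noc2C(C)C)ccc1N(C)C(=O)c1ccc(C(=O)O)cc1`: 2030 nM
Compound 3 `CC(C)c1onc(-c2c(Cl)cccc2Cl)c1COc1ccc(N(C)C(=O)c2cccc(C(=O)O)c2)c(C(F)(F)F)n1`: 571 nM

All three were tested in a functional assay on HEK293 cells for agonist activity at Bile acid receptor (Homo sapiens); a lower number here means that less compound is needed, a higher number that more compound is needed for the effect. Compound 3 gives 571 nM, the second highest of the three numbers; compound 1 sits within the scatter of it, as a 1.8-fold higher number from compound 1 to compound 3 (0.26 log units; within the scatter) shows, while compound 2, with 2030 nM, lies further away. Compound 4 `CC(C)c1onc(-c2c(Cl)cccc2Cl)c1COc1ccc(N(C)Cc2cccc(C(=O)O)c2)c(C(F)(F)F)n1` has not yet been measured. It differs from compound 3 in one place: 3-carboxybenzyl in place of (3-carboxyphenyl)carbonyl on a nitrogen on an aromatic ring. Neither measured step touches this part of the molecule: a 6.4-fold higher number from compound 1 to compound 2 (0.81 log units; beyond the scatter) concerns a group on the shared core, and a 1.8-fold higher number from compound 1 to compound 3 (0.26 log units; within the scatter) moves the acid around the ring while keeping the carbonyl. For compound 4 a modest rise in the number is expected, a 2.6-fold higher number from compound 3 to compound 4 (0.42 log units; beyond the scatter), with wide uncertainty. Compound 4 is estimated at 1500 nM, between 400 nM and 6000 nM.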

Compound 4, half-maximal effective concentration: 80 nM
Estimate against measurement, compound 4: 19-fold (1.27 log units) above; measured number outside the range, below it.
By their numbers in this assay, from the lowest: compound 4; then compounds 1 and 3 (each within the scatter of the next); then compound 2.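

The carbonyl attached to this nitrogen is not required for agonist activity in this assay: 3-carboxybenzyl in place of (3-carboxyphenyl)carbonyl removes it and gives a 7.1-fold lower number from compound 3 to compound 4 (0.85 log units; beyond the scatter), the first change shown at this link. The benzyl compound also improves on the other amide, with a 4.0-fold lower number from compound 1 to compound 4 (0.60 log units; beyond the scatter), although that step moves the acid around the ring as well. Nothing measured here explains the gain. Open questions are how 4-carboxybenzyl would compare on this nitrogen and whether a longer chain carrying the carboxylic acid would hold the gain.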